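Swapping the Benzyl Group on a Triazolopyrimidine Cytotoxicity Series

A few compounds are considered here, and "the series" means these few. Any claim that something is new, unique, unknown or untested is made for them only; others in the source may bear on it.

Measured compounds:
- compound 1, `Cc1cc(Nc2cc(-c3ccccc3)[nH]n2)n2nc(SCc3ccc(F)cc3)nc2n1`, 35500 nM
- compound 2, `Cc1nc2nc(SCc3ccc(Cl)cc3)nn2c(Nc2cc(-c3ccccc3)[nH]n2)c1C`, 47200 nM
- compound 3, `Cc1cc(Nc2ccn(Cc3ccc(F)cc3)n2)n2nc(SCc3ccc(Br)cc3)nc2n1`, 40500 nM

These three compounds share a common core and were tested in an ADME assay on GES1 cells (Homo sapiens) for inhibition, read by MTT assay, with a stated time of 72 h; a higher number here means a weaker inhibitor, a lower number a stronger inhibitor. All three numbers lie close together. Compound 1 sits at the low end of the three, but the gap to compound 3 and the gap to compound 2 both fall within the usual scatter of repeated measurements, so nothing separates them with confidence.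

The step of interest goes from compound 1 to the unmeasured compound 4, `Cc1cc(Nc2cc(-c3ccccc3)[nH]n2)n2nc(SCC(=O)c3ccccc3)nc2n1`. The change is benzoyl in place of 4-fluorophenyl on a saturated chain carbon bound to a sulfur. Put another way, the 4-fluorobenzyl group on the sulfur becomes a benzoylmethyl group.

Within the data shown here, no pair of measured compounds differs in this one place, so there is no direct precedent for the size of the step. The three measured values show that changes at this side chain and elsewhere left the numbers within the scatter of one another. On that basis the step of a 1.1-fold higher number from compound 1 to compound 4 (0.05 log units; within the scatter) is expected to be small, with no clear direction beyond the scatter. Compound 4 is therefore estimated at 40000 nM, within a range from 15000 nM to 110000 nM.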

Compound 4, half-maximal inhibitory concentration: 33300 nM
For compound 4 the middle estimate is 1.2-fold (0.08 log units) above the measured one; the measured number falls inside the stated range.
By their numbers in this assay, from the lowest: compounds 4, 1, 3 and 2 (each within the scatter of the next).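

The one-place comparison at this position shows that in this assay, benzoyl in place of 4-fluorophenyl on a saturated chain carbon bound to a sulfur gives a 1.1-fold lower number from compound 1 to compound 4 (0.03 log units; within the scatter). The entering group is larger by one heavy atom and carries one hydrogen-bond acceptor where the leaving group has none, yet the two numbers cannot be told apart. Nothing further is available to explain this result.

As far as these compounds go, it remains open whether an amine or a carboxylic acid on that saturated chain carbon, or a longer chain on the sulfur, would move the number beyond the scatter. Also open, from the compounds shown here alone, is whether the same swap would give a step this small on compound 3, which carries a different group on the shared core.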